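Aryl hydrazone series: cytotoxicity on A549 cells

A few compounds are considered here, and "the series" means these few. Any claim that something is new, unique, unknown or untested is made for them only; others in the source may bear on it.

Measured compounds:
- compound 1, `CN(C)CCn1cnnc1-c1cc(Oc2ccc(NC(=O)N/N=C/c3cc(C(C)(C)C)cc(C(C)(C)C)c3O)cc2F)ccn1`: 980 nM
- compound 2, `CN(C)CCn1cnnc1-c1cc(Oc2ccc(NC(=O)N/N=C/c3ccc(O)c(Br)c3)cc2F)ccn1`: 1370 nM

Among the measured compounds shown here, in a functional assay on A549 cells (Homo sapiens) for cytotoxicity, read by MTT assay, with a stated time of 72 h (on this read-out higher numbers stand for weaker inhibition and lower numbers for stronger inhibition), compound 2 gives 1370 nM, the higher of the two numbers so far. Its nearest neighbour is compound 1, which in this assay gives 980 nM; the gap between the two falls within the usual scatter, so the two compounds cannot be ordered against each other on these data.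

The next compound in the series is compound 3, `CN(C)CCn1cnnc1-c1cc(Oc2ccc(NC(=O)N/N=C/c3cccc(Cl)c3Cl)cc2F)ccn1`. It differs from compound 2 at a single place: 2,3-dichlorophenyl in place of 3-bromo-4-hydroxyphenyl on a carbon with a double bond to nitrogen

For the measured compounds named here, no step between measured compounds is available to calibrate this change. The entering group has no hydrogen-bond donor or acceptor, whereas the leaving group has one of each, and both measured compounds carry such a group. The step is therefore expected to run toward a higher number in this assay, of a size at about the edge of the scatter, by a 1.6-fold higher number from compound 2 to compound 3 (0.21 log units; within the scatter).

Compound 3 is accordingly estimated at 2200 nM in this assay, with a range from 700 nM to 7000 nM.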

Compound 3, half-maximal inhibitory concentration: 1090 nM
Compound 3: middle estimate off by 2.0-fold (0.30 log units), on the high side, within the range that was stated.
By their numbers in this assay, from the lowest: compounds 1, 3 and 2 (each within the scatter of the next).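

In this assay the change to 2,3-dichlorophenyl in place of 3-bromo-4-hydroxyphenyl, on a carbon with a double bond to nitrogen, gives a 1.3-fold lower number from compound 2 to compound 3 (0.10 log units; within the scatter) and so stays within the scatter. Compound 3 is the first compound shown whose aryl group at this position has no hydrogen-bond donor or acceptor, and on this read-out it cannot be told apart from compound 2, so the presence of these counted features is not needed to keep compound 3 level with compound 2 here. No measurement shown bears on this result, and the data give no explanation for the size of the step.

The compounds shown leave open whether this position stays equally insensitive to groups of another kind, such as a phenyl ring carrying a carboxylic acid or a dimethylamino group, or a plain methyl in place of the aryl ring. They also leave open whether any change at this position can produce a step beyond the scatter, and how changes elsewhere on the shared core would read in this assay.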